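The source may hold more compounds than are shown below. What is called first, only, known or untested is meant among the compounds shown, and "the series" means these compounds.

Measured so far in an assay on HEK293 cells for negative allosteric modulation of metabotropic glutamate receptor 5 (Homo sapiens), read by FLIPR, with a stated time of 1 h; on this read-out higher numbers stand for weaker inhibition and lower numbers for stronger inhibition:
Compound 1 `CN1CCc2nc(C#Cc3ccccc3)sc2C1`: > 10000 nM, a limit of the assay.
Compound 2 `O=C(C1CCCCC1)N1CCc2nc(C#Cc3ccccc3)sc2C1`: > 10000 nM, a limit of the assay.
Compound 3 `CC(C)S(=O)(=O)N1CCc2nc(C#Cc3ccccc3)sc2C1`: 11 nM.

Compound 2 stands at the limit of this assay, with no number of its own; it shares that place with one other compound (the limit of > 10000 nM in this assay, at which 2 of the 3 values shown sit). The step from compound 1 to compound 2 is a step that the two limits leave unreadable from compound 1 to compound 2. Compound 3 stands apart: the step of an at least 900-fold lower number from compound 2 to compound 3 (2.95 log units; beyond the scatter) and the step of an at least 900-fold lower number from compound 1 to compound 3 (2.95 log units; beyond the scatter) are both large. All three measured steps swap the group on the amine nitrogen in the ring, and only the isopropylsulfonyl there has given a readable number.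

Compound 4 `O=C(N1CCC(F)CC1)N1CCc2nc(C#Cc3ccccc3)sc2C1` keeps the carbonyl on that nitrogen and changes the other side of it: 4-fluoropiperidin-1-yl in place of cyclohexyl on a carbonyl carbon. Within the data shown here, no measured step touches the carbonyl carbon, and the one step that starts from compound 2 leads to a sulfonyl, not to another carbonyl. The measured data therefore give no size to carry over; the nearest point of reference is compound 2 itself, at the limit, and a carbonyl is retained. Compound 4 is expected to stay near that limit, with the expected step of a number no higher from compound 2 to compound 4 (the limit leaves the size open) not beyond the scatter. The estimate for compound 4 is 10000 nM, with a range from 2500 nM to 30000 nM.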

Compound 4, half-maximal inhibitory concentration: > 10000 nM
Compound 4 ended at the assay's limit; the forecaster's own chance of this, stated with the estimate: 70%; the middle value sits exactly at the limit.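

Compound 2 and compound 4 both stand at the assay's limit, so no step between them can be read, and compound 1 sits there too: the limit of > 10000 nM in this assay, at which 3 of the 4 values shown sit.

The compounds shown leave open whether any carbonyl-linked group on the amine nitrogen in the ring can give a readable number, as the isopropylsulfonyl of compound 3 does.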